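Methoxy for Chloro: Expecting No Real Shift in Cytotoxicity

This account rests on a few compounds, and the source may have more. Where it says the series, first, only, none or still open, it means among the compounds named here.

Two close relatives open the set. Compound 1 `CC1=NNC(=O)C1C(c1c(-c2ccccc2)[nH]c2ccc(C)cc12)c1c(-c2ccccc2)[nH]c2ccc(C)cc12` was tested in a functional assay on A549 cells (Homo sapiens) for cytotoxicity, read by MTT assay (on this read-out higher numbers stand for weaker inhibition and lower numbers for stronger inhibition), where compound 1 gives 37000 nM. Compound 2 `CC1=NNC(=O)C1C(c1c(-c2ccccc2)[nH]c2ccc(C)cc12)c1c(-c2ccccc2)[nH]c2ccc(Cl)cc12` differs from it in a single spot, and in this assay compound 2 gives 35000 nM. Among the compounds with values here, the only step measured so far, a 1.1-fold lower number from compound 1 to compound 2 (0.02 log units; within the scatter), shows that exchanging these two groups hardly moves the read-out. Of the two numbers, compound 2 has the lower one, yet its distance to compound 1 lies within the scatter, so neither compound can be called more potent than the other.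

Compound 3 `COc1ccc2[nH]c(-c3ccccc3)c(C(c3c(-c4ccccc4)[nH]c4ccc(C)cc34)C3C(=O)NN=C3C)c2c1` has not been measured. Its change from compound 2 is methoxy in place of chloro on an aromatic carbon. Within the data shown here, no measured step involves a methoxy group, so the only guide is a 1.1-fold lower number from compound 1 to compound 2 (0.02 log units; within the scatter), which stayed within the scatter. In this assay no step beyond the scatter is therefore expected, in either direction. For compound 3 the expected value in this assay is 36000 nM, with a range from 15000 nM to 90000 nM. The estimate for compound 3 thus means an expected step of a 1.0-fold higher number from compound 2 to compound 3 (0.01 log units; within the scatter).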

Compound 3, half-maximal inhibitory concentration: 1800 nM
Beside the measured number, compound 3's estimate is 20-fold (1.30 log units) above it; the measured number lies below the stated range.
By their numbers in this assay, from the lowest: compound 3; then compounds 2 and 1 (each within the scatter of the next).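

In this assay this position on the aromatic carbon turns out to be far from indifferent, which the earlier pair could not show: there is a 19-fold lower number from compound 2 to compound 3 (1.29 log units; beyond the scatter) and also a 21-fold lower number from compound 1 to compound 3 (1.31 log units; beyond the scatter) when methoxy takes the place of either earlier group. Methyl and chloro had given numbers within the scatter of each other, so their similarity says little about other groups at this position, and methoxy is the first one here to produce a large step. The count of atoms shows that methoxy brings 1 hydrogen-bond acceptor where chloro has 0 hydrogen-bond acceptors, but no measurement available here links that difference, or any other, to the lower number.

On these data alone, it stays open whether the oxygen alone accounts for the step, which a hydroxy group or an amine at the same place could test, and whether a longer chain such as ethoxy would keep it. Also open, as far as these compounds go, is whether methoxy would have a similar effect on the other half of the shared core, which keeps its methyl in compound 3.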